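The source may hold more compounds than are shown below. What is called first, only, known or untested is meant among the compounds shown, and "the series" means these compounds.

Compound 1 `COc1ccc(NC(=O)COc2cc(C)nc3ccc(OC)cc23)cc1`: in an ADME assay on HepG2 cells (Homo sapiens) for cytotoxicity, read by trypan blue exclusion, with a stated time of 48 h, in the presence of a further agent that is not named here (on this read-out higher numbers stand for lower toxicity in this test and lower numbers for higher toxicity in this test), compound 1 gives > 142000 nM, which is a limit of the assay rather than a number .
Compound 2 `COc1ccc2nc(C)cc(OCC(=O)Nc3ccccc3Cl)c2c1`: in this assay compound 2 gives > 140000 nM, again only a limit .
Compound 3 `COCCNC(=O)COc1cc(C)nc2ccc(OC)cc12`: in this assay compound 3 gives > 164000 nM, also a limit .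

All three share the same core and differ only in the group on the amide-type nitrogen. Compound 3 therefore has no definite standing on these numbers: its own value is a limit, and the two other values shown are limits as well (the limit of > 140000 nM in this assay, at which 1 of the 3 values shown sits, (the limit of > 142000 nM in this assay, at which 1 of the 3 values shown sits), (the limit of > 164000 nM in this assay, at which 1 of the 3 values shown sits)). None of the steps between the three can be read: a step that the two limits leave unreadable from compound 1 to compound 3, a step that the two limits leave unreadable from compound 2 to compound 3 and a step that the two limits leave unreadable from compound 1 to compound 2 all lie between limits.

Compound 4 `C#CCNC(=O)COc1cc(C)nc2ccc(OC)cc12` has not yet been measured. It differs from compound 3 by ethynyl in place of methoxymethyl on a saturated chain carbon bound to an amide-type nitrogen. The measured steps that bear on this are the two that also swap the group on the amide-type nitrogen, and both are unreadable, so no size can be taken from them. No step beyond the scatter is expected in either direction; the expectation is that compound 4 again reaches only a limit. Compound 4 is expected to give 150000 nM in this assay, within 50000 nM to 400000 nM. The step this estimate means is an at least 1.0-fold lower number from compound 3 to compound 4 (0.03 log units; that floor lies within the scatter), expected to stay within the scatter.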

Compound 4, half-maximal cytotoxic concentration: > 176000 nM
Compound 4 was reported as a limit (the forecaster's own chance of this, stated with the estimate: 80%); middle value at least 1.1-fold (0.06 log units) away from the limit.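

In this assay compound 4 also reaches only a limit, so the steps linking it to compound 1, compound 2 and compound 3 cannot be read: the limit of > 176000 nM in this assay, at which 1 of the 4 values shown sits. The compounds shown leave open whether changing the group on the amide-type nitrogen alters toxicity in this assay at all, and none of the four has a definite number.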